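A few compounds are considered here, and "the series" means these few. Any claim that something is new, unique, unknown or untested is made for them only; others in the source may bear on it.

Of the compounds shown here, three built on one shared core have so far been measured in a functional assay on HeLa cells (Homo sapiens) for inhibition, read by MTT assay, with a stated time of 48 h; a lower number here means a stronger inhibitor, a higher number a weaker inhibitor. Compound 1 `COc1ccc2c(=O)c(/C=C/C(=O)Nc3cccc(Cl)c3)coc2c1` gives 11900 nM. Compound 2 `COc1ccc2c(=O)c(/C=C/C(=O)NCc3ccccc3)coc2c1`, with benzyl in place of 3-chlorophenyl on the amide-type nitrogen, gives 33400 nM, a change of a 2.8-fold higher number from compound 1 to compound 2 (0.45 log units; beyond the scatter). Compound 3 `COc1ccc(CNC(=O)/C=C/c2coc3cc(OC)ccc3c2=O)cc1` is recorded only as a limit of this assay, > 100000 nM. Its standing is therefore known only as the weakest end of the series, resting on (the limit of > 100000 nM in this assay, at which 1 of the 3 values shown sits). The two steps into it are an at least 8.4-fold higher number from compound 1 to compound 3 (0.92 log units; beyond the scatter) and an at least 2.9-fold higher number from compound 2 to compound 3 (0.47 log units; beyond the scatter), both beyond the scatter.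

Compound 4 `COc1ccc2c(=O)c(/C=C/C(=O)Nc3ccc(F)cc3)coc2c1` has not yet been measured in this assay. It differs from compound 3 by 4-fluorophenyl in place of 4-methoxybenzyl on an amide-type nitrogen. The relevant measured steps are those leaving compound 1: replacing 3-chlorophenyl by benzyl cost a modest amount, and replacing it by 4-methoxybenzyl cost at least a larger amount. Compound 4 reverses that direction, returning a 4-fluorophenyl rather than a benzyl-type group to the amide-type nitrogen, so a drop of similar size is expected, an at least 6.6-fold lower number from compound 3 to compound 4 (0.82 log units; beyond the scatter), toward the region of compound 1. Compound 4 is estimated to give 15000 nM, within a range from 5000 nM to 60000 nM.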

Compound 4, half-maximal inhibitory concentration: 9680 nM
Compound 4: the middle estimate sits 1.5-fold (0.19 log units) above what was measured; the measured number falls inside the stated range.
By their numbers in this assay, from the lowest: compounds 4 and 1 (each within the scatter of the next); then compound 2. At a limit, above all of these: compound 3.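

A second substituted phenyl group now stands on the amide-type nitrogen alongside 3-chlorophenyl, and in this assay the two cannot be told apart, with a 1.2-fold lower number from compound 1 to compound 4 (0.09 log units; within the scatter). Both benzyl-type groups give higher numbers than 4-fluorophenyl, with a 3.5-fold lower number from compound 2 to compound 4 (0.54 log units; beyond the scatter) for the change from benzyl and an at least 10-fold lower number from compound 3 to compound 4 (1.01 log units; beyond the scatter) for the change from 4-methoxybenzyl, so among these four compounds the two phenyl groups stand together, clearly apart from the two benzyl-type groups. The size of the step from 4-methoxybenzyl has only a lower bound, as compound 3 is recorded only as a limit of the assay: the limit of > 100000 nM in this assay, at which 1 of the 4 values shown sits.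

On these data alone, what an unsubstituted phenyl or a 4-methoxyphenyl on the amide-type nitrogen would give remains open, so the part played by the chlorine and fluorine cannot be separated from that of the phenyl ring itself. Also open, as far as these compounds go, is how a longer chain such as 2-phenylethyl, or a phenyl ring carrying a carboxylic acid or an amine, would read in this assay.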